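A few compounds are considered here, and "the series" means these few. Any claim that something is new, unique, unknown or untested is made for them only; others in the source may bear on it.

Three compounds share one core and differ only in the aromatic group that hangs from the benzyl ring. In an assay on microsomes from intestine for inhibition of acyl-CoA:cholesterol acyltransferase (Oryctolagus cuniculus) (a lower number here means a stronger inhibitor, a higher number a weaker inhibitor), compound 1 `Cc1cc(C)c(NC(=O)N(Cc2ccc(-c3n[nH]c(C)n3)cc2)C2CCCCCC2)c(C)c1` gives 120 nM. Compound 2 `Cc1cc(C)c(NC(=O)N(Cc2ccc(-c3cccs3)cc2)C2CCCCCC2)c(C)c1` gives 22 nM in this assay, and compound 3 `Cc1cc(C)c(NC(=O)N(Cc2ccc(-c3ccccn3)cc2)C2CCCCCC2)c(C)c1` gives 33 nM. Swapping the triazolyl group for a thiophenyl group brought a 5.5-fold lower number from compound 1 to compound 2 (0.74 log units; beyond the scatter), and swapping it for a pyridinyl group brought a 3.6-fold lower number from compound 1 to compound 3 (0.56 log units; beyond the scatter); between the two six-membered and five-membered alternatives the step was a 1.5-fold higher number from compound 2 to compound 3 (0.18 log units; within the scatter). Compound 3 therefore stands second highest of the three numbers, within the scatter of compound 2 and clearly separated from compound 1.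

Compound 4 `Cc1cc(C)c(NC(=O)N(Cc2ccc(-c3cccnc3)cc2)C2CCCCCC2)c(C)c1` keeps every atom of compound 3 and only rejoins them: pyridin-3-yl in place of pyridin-2-yl on an aromatic carbon. No measured step moves the ring nitrogen in this way; the closest comparison, the small step from compound 2 to compound 3, suggests that changes among these small aromatic groups are gentle. The step from compound 3 to compound 4 is expected to be a 1.2-fold higher number from compound 3 to compound 4 (0.08 log units; within the scatter), which is not beyond the scatter. Compound 4 is estimated at 40 nM in this assay, with a likely range from 15 nM to 130 nM.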

Compound 4, half-maximal inhibitory concentration: 130 nM
Compound 4: middle estimate off by 3.3-fold (0.51 log units), on the low side; the range from low to high includes it.
By their numbers in this assay, from the lowest: compounds 2 and 3 (each within the scatter of the next); then compounds 1 and 4 (each within the scatter of the next).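

In this assay the move from pyridin-2-yl to pyridin-3-yl gives a 3.9-fold higher number from compound 3 to compound 4 (0.60 log units; beyond the scatter) even though no atom is added or lost, so the place of the ring nitrogen matters here, whereas the earlier swap of thiophen-2-yl for pyridin-2-yl stayed within the scatter. The new group also stands apart from thiophen-2-yl, with a 5.9-fold higher number from compound 2 to compound 4 (0.77 log units; beyond the scatter) as the step, while a 1.1-fold higher number from compound 1 to compound 4 (0.03 log units; within the scatter) leaves it level with 5-methyl-1H-1,2,4-triazol-3-yl. A pyridine ring alone therefore does not secure the lower numbers: of the two pyridinyl groups, only pyridin-2-yl sits with thiophen-2-yl.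

On these data alone, whether pyridin-4-yl, a plain phenyl ring or a pyridin-2-yl ring carrying an amine would join the lower or the higher numbers stays open. Nothing available here bears on why moving the ring nitrogen makes this difference.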